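Swapping one dimethylphenyl for another in a cytotoxicity series

This account rests on a few compounds, and the source may have more. Where it says the series, first, only, none or still open, it means among the compounds named here.

- compound 1 `Cc1cc(S(N)(=O)=O)ccc1NC(=O)COc1ccc(Cl)cc1C(O)c1ccccc1Cl` gives 32000 nM
- compound 2 `Cc1cc(S(N)(=O)=O)ccc1NC(=O)COc1ccc(Cl)cc1C(O)c1cccc([N+](=O)[O-])c1` gives 36900 nM
- compound 3 `Cc1ccc(C(O)c2cc(Cl)ccc2OCC(=O)Nc2ccc(S(N)(=O)=O)cc2C)c(C)c1` gives 26400 nM

In an ADME assay on C8166 cells (Homo sapiens) for cytotoxicity, read by MTT assay (on this read-out higher numbers stand for lower toxicity in this test and lower numbers for higher toxicity in this test), compound 3 gives 26400 nM and stands within the scatter of both other compounds, with measured steps of a 1.2-fold lower number from compound 1 to compound 3 (0.08 log units; within the scatter) and a 1.4-fold lower number from compound 2 to compound 3 (0.15 log units; within the scatter) between them. Compound 4 `Cc1cc(C)cc(C(O)c2cc(Cl)ccc2OCC(=O)Nc2ccc(S(N)(=O)=O)cc2C)c1` has not yet been measured. It differs from compound 3 by one change, 3,5-dimethylphenyl in place of 2,4-dimethylphenyl on a saturated chain carbon bound to an aromatic carbon and an oxygen on a saturated carbon in all, with the same atoms joined differently: 3,5-dimethylphenyl in place of 2,4-dimethylphenyl on a saturated chain carbon bound to an aromatic carbon and an oxygen on a saturated carbon. Within the data shown here, no measured pair shows this exact swap. The nearest evidence is the two steps above, along with a 1.2-fold higher number from compound 1 to compound 2 (0.06 log units; within the scatter) at the same place. None of them leaves the scatter, so no step beyond it is expected in this assay here. The expected step is only a 1.1-fold higher number from compound 3 to compound 4 (0.04 log units; within the scatter) in size. For compound 4 the estimated value is 29000 nM with an expected range of 18000 nM to 47000 nM in this test.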

Compound 4, half-maximal cytotoxic concentration: 29400 nM
Compound 4: middle estimate off by 1.0-fold (0.01 log units), on the low side; low and high end bracket the measured number.
By their numbers in this assay, from the lowest: compounds 3, 4, 1 and 2 (each within the scatter of the next).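

In this assay, the 3,5-dimethylphenyl group in place of the 2,4-dimethylphenyl group, the same atoms joined differently, gives a 1.1-fold higher number from compound 3 to compound 4 (0.05 log units; within the scatter) and so offers the first view of a rearrangement of the same methyl groups alone on this saturated chain carbon. The new group also shows a 1.3-fold lower number from compound 2 to compound 4 (0.10 log units; within the scatter) and a 1.1-fold lower number from compound 1 to compound 4 (0.04 log units; within the scatter) in comparison with the 3-nitrophenyl and 2-chlorophenyl groups, so all four aryl groups at this place now stand within the scatter of one another in this test. No measurement on hand bears on why the arrangement of the methyl groups makes no readable difference here. On these data alone, all four compounds carry a substituted phenyl group at this place, so it remains open whether an amine, a carboxylic acid or a longer chain there would give a step beyond the scatter. The same holds for an unsubstituted phenyl group.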